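This account rests on a few compounds, and the source may have more. Where it says the series, first, only, none or still open, it means among the compounds named here.

Values in an ADME assay on HPLF cells (Homo sapiens) for cytotoxicity, with a stated time of 24 h; a lower number here means that less compound is tolerated, a higher number that more compound is tolerated:
- Compound 1 `O=C1/C(=C/c2ccccc2)CCC/C1=C\c1ccccc1[N+](=O)[O-]`: 26000 nM
- Compound 2 `COc1cc(/C=C2\CCC/C(=C\c3cccc([N+](=O)[O-])c3)C2=O)cc(OC)c1OC`: > 400000 nM, a limit of the assay and not a number
- Compound 3 `O=C1/C(=C/c2ccccc2)CCC/C1=C\c1ccc([N+](=O)[O-])cc1`: 282000 nM

Of the two true numbers, compound 3 holds the higher, and compound 1 at 26000 nM lies beyond the scatter below it. Compound 4 `O=C1/C(=C/c2ccc(Cl)cc2)CCC/C1=C\c1ccc([N+](=O)[O-])cc1` is compound 3 with one change, chloro in place of hydrogen on an aromatic carbon, turning phenyl to 4-chlorophenyl. Within the data shown here, no measured pair here shows this change, so any prediction is uncertain. The expected step, a 1.9-fold lower number from compound 3 to compound 4 (0.27 log units; within the scatter), is a modest one toward a lower number, close to the scatter. The numbers of compound 1 and compound 3 lie far apart, so the range is kept wide. For compound 4 the estimated value is 150000 nM, with an expected range of 40000 nM to 400000 nM.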

Compound 4, half-maximal cytotoxic concentration: 332000 nM
The estimate for compound 4 lay 2.2-fold (0.35 log units) below the measured number; low and high end bracket the measured number.
By their numbers in this assay, from the lowest: compound 1; then compounds 3 and 4 (each within the scatter of the next). At a limit, above all of these: compound 2.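

In this assay, turning phenyl to 4-chlorophenyl gives a 1.2-fold higher number from compound 3 to compound 4 (0.07 log units; within the scatter), so compound 3 and compound 4 cannot be told apart in this assay. Among these compounds, this is the first direct comparison of compounds that differ in one place, and it shows that chloro at this position on the aromatic ring is tolerated without a step beyond the scatter. Compound 2 remains at a limit of the assay and not a number: the limit of > 400000 nM in this assay, at which 1 of the 4 values shown sits.

As far as these compounds go, whether an amine or a carboxylic acid at the same position would also stay within the scatter remains open. So does whether chloro would give a similar step on the core of compound 1.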